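The source may hold more compounds than are shown below. What is called first, only, known or untested is meant among the compounds shown, and "the series" means these compounds.

Compound 1 `CCOC(=O)c1cnn(-c2nc(-c3ccc(OC)cc3)c(C#N)c(=O)n2C)c1N`: 79 ug/mL
Compound 2 `CN(C)c1ccc(-c2nc(NN)n(C)c(=O)c2C#N)cc1`: 69 ug/mL

In a functional assay, with a stated time of 150 min (a higher number here means a weaker inhibitor, a lower number a stronger inhibitor), compound 1 gives 79 ug/mL and compound 2 gives 69 ug/mL. These two numbers lie within the usual scatter of each other, so neither compound counts as the stronger inhibitor. Compound 3 `CCOC(=O)c1cnn(-c2nc(-c3cccs3)c(C#N)c(=O)n2C)c1N` has thiophen-2-yl in place of the 4-methoxyphenyl of compound 1, on an aromatic carbon of the shared core: thiophen-2-yl in place of 4-methoxyphenyl on an aromatic carbon. Going by the values given here, no measured pair shows this kind of swap, so the data point in no direction, and no step beyond the scatter is expected. The expected change is a 1.1-fold lower number from compound 1 to compound 3 (0.05 log units; within the scatter). The estimated value for compound 3 is 70 ug/mL, with an expected range of 30 ug/mL to 160 ug/mL.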

Compound 3, half-maximal inhibitory concentration: 98 ug/mL
Compound 3: middle estimate off by 1.4-fold (0.15 log units), on the low side; measured number inside the range.
By their numbers in this assay, from the lowest: compounds 2, 1 and 3 (each within the scatter of the next).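

In this assay, going by these compounds alone, the first measured swap at this position, thiophen-2-yl in place of 4-methoxyphenyl, gives a 1.2-fold higher number from compound 1 to compound 3 (0.09 log units; within the scatter) and so does not separate the two compounds. At this aromatic carbon, a five-membered ring with sulfur can therefore stand in for the larger six-membered carbon ring without a readable shift in the number. No measurement at hand gives a reason for this.

From the compounds shown here alone, whether an amine or a carboxylic acid on this carbon would move the number beyond the scatter remains open. The same holds for an unsubstituted phenyl ring or a longer alkyl chain.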